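Replacing the arylamine of compound 2 with a pyrrolidinyloxy group

A few compounds are considered here, and "the series" means these few. Any claim that something is new, unique, unknown or untested is made for them only; others in the source may bear on it.

Compound 1 `Cc1ccc(Nc2ncc3c(n2)N(C)C(=O)N(c2cc(NC(=O)c4cccc(C(F)(F)F)c4)ccc2C)C3)cc1C` gives 17 nM in a functional assay on K562 cells (Homo sapiens) for antiproliferative activity, read by CellTiter-Glo and CCK-8 assay, with a stated time of 72 h; on this read-out lower numbers stand for stronger inhibition of growth and higher numbers for weaker inhibition of growth.
Compound 2 `CNc1cc(Nc2ncc3c(n2)N(C)C(=O)N(c2cc(NC(=O)c4cccc(C(F)(F)F)c4)ccc2C)C3)ccc1C` gives 19 nM in this assay.

Compound 2 has the highest of the two numbers, and its nearest neighbour is compound 1, differing by a 1.1-fold higher number from compound 1 to compound 2 (0.05 log units; within the scatter), which does not separate the two. Compound 3 `Cc1ccc(NC(=O)c2cccc(C(F)(F)F)c2)cc1N1Cc2cnc(O[C@H]3CCNC3)nc2N(C)C1=O` carries a different change: (pyrrolidin-3-yl)oxy in place of (4-methyl-3-(methylamino)phenyl)amino on an aromatic carbon. For the measured compounds named here, the one measured step, a 1.1-fold higher number from compound 1 to compound 2 (0.05 log units; within the scatter), alters a substituent on the arylamine ring that is removed altogether in compound 3, so it offers no direct guide to exchanging that whole group for a pyrrolidinyloxy. Going by the values given here, with no comparable step in hand, compound 3 is expected to show a weaker result, with a 7.9-fold higher number from compound 2 to compound 3 (0.90 log units; beyond the scatter) as the estimated shift. The estimate for compound 3 in this assay is therefore 150 nM, with a range from 30 nM to 800 nM.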

Compound 3, concentration for 50% growth inhibition: 450 nM
For compound 3 the middle estimate is 3.0-fold (0.48 log units) below the measured one, within the range that was stated.
By their numbers in this assay, from the lowest: compounds 1 and 2 (each within the scatter of the next); then compound 3.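

In this assay the exchange of (4-methyl-3-(methylamino)phenyl)amino for (pyrrolidin-3-yl)oxy gives a 24-fold higher number from compound 2 to compound 3 (1.37 log units; beyond the scatter), and the exchange of (3,4-dimethylphenyl)amino for the same group gives a 26-fold higher number from compound 1 to compound 3 (1.42 log units; beyond the scatter). For the compounds shown here, the earlier pair showed only that the two arylamine groups could not be separated in this assay; compound 3 shows that the read-out at this position, on an aromatic carbon between two ring nitrogen atoms, does move when the whole arylamine is replaced. No evidence is available to account for this large shift.

The change swaps the linking nitrogen for oxygen and the aromatic ring for a non-aromatic one at once, so the compounds shown cannot tell these two apart. On these data alone, a (pyrrolidin-3-yl)amino group or a phenoxy group would separate them, and the opposite stereocentre of the pyrrolidine also remains open.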